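The compounds below may be only part of what the source reports. "The series", "measured", "known", "first", "only" and "open" are said of these compounds alone.

Measured in a functional assay on A2780 cells (Homo sapiens) for cytotoxicity, read by sulforhodamine B assay, with a stated time of 72 h; a higher number here means a weaker inhibitor, a lower number a stronger inhibitor:
- compound 1 `CCCn1cc(S(=O)(=O)c2ccc(CNC(=O)N3Cc4ccncc4C3)cc2)cn1` gives 7.3 nM
- compound 2 `O=C(NCc1ccc(S(=O)(=O)C2CCOCC2)cc1)N1Cc2ccncc2C1` gives 35 nM
- compound 3 `CCC(=O)N1CCC(S(=O)(=O)c2ccc(CNC(=O)N3Cc4ccncc4C3)cc2)CC1` gives 54 nM

Compound 3 has the highest of the three numbers, but only the gap to compound 1 lies beyond the scatter (a 7.4-fold higher number from compound 1 to compound 3 (0.87 log units; beyond the scatter)). Its gap to compound 2 lies within it (a 1.5-fold higher number from compound 2 to compound 3 (0.19 log units; within the scatter)).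

Next is compound 4 `O=C(NCc1ccc(S(=O)(=O)C2CCN(C3COC3)CC2)cc1)N1Cc2ccncc2C1`, with oxetan-3-yl in place of propanoyl on an amine nitrogen in a ring. For the measured compounds named here, no measured step touches that nitrogen, so the evidence is indirect and comes from changes on the sulfonyl sulfur. Leaving 1-propyl-1H-pyrazol-4-yl gave a modest step (a 4.8-fold higher number from compound 1 to compound 2 (0.68 log units; beyond the scatter)), as did the change behind compound 3 noted above. Exchanging oxan-4-yl for 1-propanoylpiperidin-4-yl did not move the number beyond the scatter. On that basis, no step beyond the scatter is expected in this assay, and no direction is favoured.

The estimated step is small (a 1.4-fold lower number from compound 3 to compound 4 (0.13 log units; within the scatter)). For compound 4 the expected value is 40 nM, with an estimated range of 12 nM to 130 nM.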

Compound 4, half-maximal inhibitory concentration: 7.4 nM
Compound 4: the middle estimate sits 5.4-fold (0.73 log units) above what was measured, outside the stated range (below it).
By their numbers in this assay, from the lowest: compounds 1 and 4 (each within the scatter of the next); then compounds 2 and 3 (each within the scatter of the next).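

At the amine nitrogen of the six-membered ring, the exchange of propanoyl for oxetan-3-yl gives the first step measured at this position in this assay (a 7.3-fold lower number from compound 3 to compound 4 (0.86 log units; beyond the scatter)), so this substituent can move the number beyond the scatter even with the heavy atom count unchanged. The 1-(oxetan-3-yl)piperidin-4-yl group also separates from oxan-4-yl on the sulfonyl sulfur (a 4.7-fold lower number from compound 2 to compound 4 (0.67 log units; beyond the scatter)) but not from 1-propyl-1H-pyrazol-4-yl (a 1.0-fold higher number from compound 1 to compound 4 (0.01 log units; within the scatter)), which shows that a non-aromatic group at the sulfonyl sulfur can match compound 1. Nothing available here explains the step at the nitrogen.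

With only propanoyl and oxetan-3-yl shown on that nitrogen, it remains open whether the step follows from gaining the oxetane ring or from losing the propanoyl carbonyl. The unsubstituted piperidine amine, a methyl group or a cyclobutyl ring at the same nitrogen would separate these two readings.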